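Moving the methoxy group on the anilide ring

The source may hold more compounds than are shown below. What is called first, only, known or untested is meant among the compounds shown, and "the series" means these compounds.

Among the measured compounds shown here, compound 2, `COc1ccc(NC(=O)/C=C/c2coc3cc(OC)ccc3c2=O)cc1`, is the only compound with a number in a functional assay on A549 cells (Homo sapiens) for inhibition, read by MTT assay, with a stated time of 48 h; a lower number here means a stronger inhibitor, a higher number a weaker inhibitor: compound 2 gives 23000 nM. Compound 1, `COc1ccc2c(=O)c(/C=C/C(=O)NCc3ccccc3F)coc2c1`, reaches only a limit in this assay, > 100000 nM, and so is known just as being at or beyond the limit of the limit of > 100000 nM in this assay, at which 1 of the 2 values shown sits. For the measured compounds named here, the one measured step, an at least 4.3-fold lower number from compound 1 to compound 2 (0.63 log units; beyond the scatter), exchanges a benzyl-type group for an aryl group and does not touch where the methoxy group sits. Compound 3, `COc1ccc2c(=O)c(/C=C/C(=O)Nc3ccccc3OC)coc2c1`, differs from compound 2 by 2-methoxyphenyl in place of 4-methoxyphenyl on an amide-type nitrogen. Going by the values given here, no measured step bears on this change, so compound 3 is expected to stay close to compound 2 in this assay, with a step of a 1.3-fold higher number from compound 2 to compound 3 (0.12 log units; within the scatter) that may fall within the scatter. Compound 3 is therefore estimated at 30000 nM, between 8000 nM and 120000 nM.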

Compound 3, half-maximal inhibitory concentration: > 100000 nM
Compound 3 gave a limit, no number; the forecaster's own chance of this, stated with the estimate: 25%; middle value at least 3.3-fold (0.52 log units) away from the limit.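

In this assay, exchanging 4-methoxyphenyl for 2-methoxyphenyl on the amide-type nitrogen gives an at least 4.3-fold higher number from compound 2 to compound 3 (0.63 log units; beyond the scatter), although the two groups have the same atoms. Among the compounds shown here, the earlier step had replaced the whole group on this nitrogen, whereas this one shows that the place of the methoxy group on the ring alone is enough to make a difference beyond the scatter, and compound 2 remains the only compound with a number. The step from compound 1 to compound 3 joins two limits and cannot be read, and most of the series now stands at one end of the scale: the limit of > 100000 nM in this assay, at which 2 of the 3 values shown sit.

From the compounds shown here alone, the full size of the step to compound 3 stays open, as that compound gave only a limit. Also open, going by these compounds, is whether a hydroxy group, a chlorine atom or an ethoxy group in place of the methoxy group of compound 2 would give a number in this assay.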